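Metabolic stability across the series: from compound 2 to compound 4

The source may report more compounds than this note shows. Statements on the series, on what has been measured and on what is new or still open speak of the compounds shown alone.

Of the compounds shown here, three have been measured in an ADME assay on microsomes from liver (Homo sapiens) for metabolic stability, read by LC-MS, with NADPH named in the record, with a stated time of 60 min, tested at 1 uM, in the absence of a further agent; on this read-out lower numbers stand for a less stable compound and higher numbers for a more stable compound. Compound 1 `CC(=O)N[C@@H]1CCN(c2cc(C)nn3c(-c4ccc(OC(F)(F)F)cc4)c(C)nc23)C1` gives > 95%, a limit of the assay. Compound 3 `COc1ccc(-c2c(C)nc3c(N4CC=CC4)cc(C)nn23)cc1OC` is likewise reported only as a limit, > 95%. Compound 2 `COc1ccc(-c2c(C)nc3c(N4CC[C@@H](NC(=O)Nc5ccccc5)C4)cc(C)nn23)cc1OC` stands at a limit as well, > 95%. For the measured compounds named here, the measured picture is therefore (the limit of > 95% in this assay, at which 3 of the 3 values shown sit), and no step between measured compounds can be read from it. Compound 4 `COc1ccc(-c2c(C)nc3c(N4CC[C@@H](n5cc(-c6ccccc6)nn5)C4)cc(C)nn23)cc1OC` differs from compound 2 in one place: 4-phenyl-1H-1,2,3-triazol-1-yl in place of (phenylcarbamoyl)amino on a saturated ring carbon. With every measured value at the limit, no direction is established; the step of a number at least 7 percentage points lower from compound 2 to compound 4 (that floor lies within the scatter) is expected to stay within the usual scatter, with some chance of a fall. Compound 4 is estimated at 88%, with a range from 65% to 98%.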

Compound 4, percent of the compound remaining: "unstable" (no number reported)
The entry for compound 4 holds no number, and the estimate cannot be compared.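

For the compounds shown here, no step from compound 2 to compound 4 can be read in this assay: compound 4 is recorded without a number, and compound 2 stands only at a limit. The compounds shown leave open how large any difference between (phenylcarbamoyl)amino and 4-phenyl-1H-1,2,3-triazol-1-yl is on this read-out.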